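Removing one chloro from the dichloro core of compound 2

This account rests on a few compounds, and the source may have more. Where it says the series, first, only, none or still open, it means among the compounds named here.

Of the compounds shown here, two have been measured in a functional assay on CCRF-CEM cells (Homo sapiens) for cytotoxicity, read by sulforhodamine B assay, with a stated time of 48 h; on this read-out higher numbers stand for weaker inhibition of growth and lower numbers for stronger inhibition of growth. Within the data shown here, compound 2 `ClCc1ccccc1Cn1cnc2nc(Cl)nc(Cl)c21` stands as the only true number in the set: in this assay compound 2 gives 300 nM. Compound 1 `ClCc1ccc(Cn2cnc3c(Cl)ncnc32)cc1` is reported only as a limit of the assay, > 100000 nM in this assay, which is the limit of > 100000 nM in this assay, at which 1 of the 2 values shown sits. Among the measured compounds shown here, compound 1 and compound 2 differ in more than one place, so no single step between them can be read; their values show only that compound 2 inhibits growth where compound 1 reaches no measurable inhibition.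

Compound 3 `ClCc1ccccc1Cn1cnc2ncnc(Cl)c21` is unmeasured. It differs from compound 2 by hydrogen in place of chloro on an aromatic carbon. For the measured compounds named here, no measured step follows this change anywhere in the set. Compound 1 also carries a single chloro on its core and reaches only the limit, but its benzyl part differs as well, so the change cannot be isolated from that pair. The expectation is a loss in this assay beyond the scatter, with an estimated step of a 10-fold higher number from compound 2 to compound 3 (1.00 log units; beyond the scatter). Compound 3 is expected at 3000 nM, between 400 nM and 50000 nM, with a real chance that only a limit is returned.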

Compound 3, concentration for total growth inhibition: 3540 nM
Estimate against measurement, compound 3: 1.2-fold (0.07 log units) below; measured number inside the range.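

Working notes on the position: on the aromatic carbon between two ring nitrogen atoms, the chloro counts for much of the growth inhibition seen in this assay, since hydrogen in its place gives a 12-fold higher number from compound 2 to compound 3 (1.07 log units; beyond the scatter), the only step in the series that can be read at a single place. The loss is not complete, as compound 3 still returns a true number of 3540 nM, so growth inhibition in this set does not depend on this chloro alone. Compound 1 remains a limit of the assay, and it differs from compound 3 in more than one place, so that pair, like compound 1 with compound 2, cannot be read as a step: the limit of > 100000 nM in this assay, at which 1 of the 3 values shown sits.

What the compounds shown leave open is whether the chloro itself is what matters at this carbon, or whether another group there, such as an amine, a methoxy or a methyl, would hold the value of compound 2. From the compounds shown here alone, the other chloro on the core and the chloromethyl group on the benzyl part also stay untested as single changes, for example hydrogen on the core or a plain methyl in place of chloromethyl.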